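A Methoxypyridine Swap at the End of the Chain

The source may report more compounds than this note shows. Statements on the series, on what has been measured and on what is new or still open speak of the compounds shown alone.

In a functional assay on SW-620 cells (Homo sapiens) for antiproliferative activity, read by MTT assay, with a stated time of 24 h (on this read-out higher numbers stand for weaker inhibition and lower numbers for stronger inhibition), compound 1 (`COc1ccc(/C=C/C(=O)c2ccc(OC)c3c2OC(C)(C)C=C3)c(F)c1`) gives 6570 nM and compound 2 (`COc1ccc(C(=O)/C=C/c2ccc([N+](=O)[O-])cc2)c2c1C=CC(C)(C)O2`) gives 3520 nM while compound 3 (`COc1ccc(C(=O)/C=C/c2cccc([N+](=O)[O-])c2)c2c1C=CC(C)(C)O2`) gives 4090 nM on the same read-out. Compound 3 stands within the scatter of both other compounds: a 1.2-fold higher number from compound 2 to compound 3 (0.07 log units; within the scatter) and a 1.6-fold lower number from compound 1 to compound 3 (0.21 log units; within the scatter) are small steps, and a 1.9-fold lower number from compound 1 to compound 2 (0.27 log units; within the scatter) also stays inside that scatter. So far, then, exchanging the ring group at this place has produced no clear difference.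

Compound 4 (`COc1ccc(/C=C/C(=O)c2ccc(OC)c3c2OC(C)(C)C=C3)cn1`) has 6-methoxypyridin-3-yl in place of 3-nitrophenyl on a double-bonded chain carbon bound to a double-bonded chain carbon, with 6-methoxypyridin-3-yl in place of 3-nitrophenyl on a double-bonded chain carbon bound to a double-bonded chain carbon as the full count of what changes. Among the measured compounds shown here, no measured compound has a ring with a hetero atom at this place, so the evidence is indirect. The nearest guide is compound 1, whose 2-fluoro-4-methoxyphenyl group also carries a methoxy group and which gives 6570 nM as its number. In this assay the expected change is a 1.2-fold higher number from compound 3 to compound 4 (0.07 log units; within the scatter) as an estimated step that stays within the scatter. For compound 4 the estimated value is 4800 nM with an expected range from 2400 nM to 9500 nM as its upper end.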

Compound 4, half-maximal inhibitory concentration: > 10000 nM
Compound 4 was reported as a limit (the forecaster's own chance of this, stated with the estimate: 3%); middle value at least 2.0-fold (0.31 log units) away from the limit.
By their numbers in this assay, from the lowest: compounds 2, 3 and 1 (each within the scatter of the next). At a limit, above all of these: compound 4.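

In this assay, among the compounds shown here, this is the first exchange of the ring group on a double-bonded chain carbon bound to a double-bonded chain carbon that clearly separates two compounds, as both nitrophenyl compounds stand apart from the new one: an at least 2.4-fold higher number from compound 3 to compound 4 (0.38 log units; beyond the scatter) and an at least 2.8-fold higher number from compound 2 to compound 4 (0.45 log units; beyond the scatter). For the compounds shown here, the comparison with the other methoxy-bearing ring is less decisive, since an at least 1.5-fold higher number from compound 1 to compound 4 (0.18 log units; that floor lies within the scatter), so 6-methoxypyridin-3-yl cannot yet be told apart from 2-fluoro-4-methoxyphenyl, and the data show only that the pyridine compound falls on the weak side of the nitrophenyl compounds. Compound 4 is reported only as a limit, not as an exact number, which means each of these steps is a minimum: the limit of > 10000 nM in this assay, at which 1 of the 4 values shown sits.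

On these data alone, how far compound 4 really lies from compound 1 remains open, and with it whether the ring nitrogen of the 6-methoxypyridin-3-yl group has any part in the change. Also open, as far as these compounds go, is what a plain phenyl ring, or a ring carrying an amine or a carboxylic acid, would give at this place on the same shared core.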